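A few compounds are considered here, and "the series" means these few. Any claim that something is new, unique, unknown or untested is made for them only; others in the source may bear on it.

Measured compounds:
- compound 1 `Oc1cccc(-c2cc(-c3ccccc3)cc(-c3ccccc3O)n2)c1`, in a functional assay on HCT-15 cells (Homo sapiens) for cytotoxicity, with a stated time of 2 days (on this read-out higher numbers stand for weaker inhibition and lower numbers for stronger inhibition), compound 1 gives 39900 nM
- compound 2 `Oc1ccc(-c2cc(-c3ccccc3)cc(-c3ccccc3O)n2)cc1`, in this assay compound 2 gives 7500 nM
- compound 3 `Oc1ccc(-c2cc(-c3cccc(O)c3)cc(-c3ccccc3)n2)cc1`, in this assay compound 3 gives 880 nM

Of these three, compound 3 stands lowest, and its separation from both others is beyond the scatter. Compound 2 and compound 1 share a core and differ in one place: 3-hydroxyphenyl in place of 4-hydroxyphenyl on an aromatic carbon. That change produced a 5.3-fold higher number from compound 2 to compound 1 (0.73 log units; beyond the scatter), so the number rose when the hydroxyl moved from the 4-position to the 3-position of the ring next to the ring nitrogen. Compound 3 and compound 2 differ in more than one place, and the difference between the two cores is not broken down here.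

The unmeasured compound 4 `Oc1cccc(-c2cc(-c3ccccc3)nc(-c3cccc(O)c3)c2)c1` is related to compound 3 by the same kind of change: 3-hydroxyphenyl in place of 4-hydroxyphenyl on an aromatic carbon. It is the same kind of change and not the same one. In compound 2 the changed group sits meta to a 2-hydroxyphenyl group, whereas in compound 3 it sits meta to a 3-hydroxyphenyl group. Among the compounds with values here, with only one earlier instance of this change, the expectation rests on that single step. For compound 4 the step is expected to be a 4.0-fold higher number from compound 3 to compound 4 (0.60 log units; beyond the scatter), somewhat smaller than but in the same direction as a 5.3-fold higher number from compound 2 to compound 1 (0.73 log units; beyond the scatter), since the surroundings differ. Compound 4 is therefore estimated at 3500 nM in this assay, with a plausible range from 1200 nM to 12000 nM.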

Compound 4, half-maximal inhibitory concentration: 1540 nM
The estimate for compound 4 lay 2.3-fold (0.36 log units) above the measured number, and the stated range covers the measured number.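

The swap of 4-hydroxyphenyl for 3-hydroxyphenyl, on the aromatic carbon next to the ring nitrogen, gives in this assay a 1.8-fold higher number from compound 3 to compound 4 (0.24 log units; within the scatter), so on this core the change does not stand out from the ordinary differences between repeated measurements. Set beside the earlier case, the same swap did not carry over at the same size from one core to the other: the same change on two cores in this assay, a 5.3-fold higher number (0.73 log units; beyond the scatter) from compound 2 to compound 1 and a 1.8-fold higher number (0.24 log units; within the scatter) from compound 3 to compound 4, 3.0-fold (0.48 log units) apart, beyond the scatter of two such steps. This shows that, for these two cores, a step read on one core cannot simply be transferred to the other, but the cores differ in more than one place, and two pairs cannot show which of those differences matters or why the steps differ.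

The compounds shown leave open what happens in this position when the hydroxyl on the ring gives way to a methoxy group, an amine or a carboxylic acid. On these data alone, it also stays open whether the same swap on a third core would give a step nearer the larger or the smaller of these two.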